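The compounds below may be only part of what the source reports. "The series", "measured", "known", "first", "only" and "open" are said of these compounds alone.

Three compounds have been measured in a functional assay on HCT-116 cells (Homo sapiens) for inhibition, read by MTT assay, with a stated time of 72 h; a higher number here means a weaker inhibitor of growth, a lower number a stronger inhibitor of growth:

Compound 1, `CN(C)c1ccc(-c2nc3c(N4CCN(Cc5ccncc5)CC4)c(Br)cnc3[nH]2)cc1`, gives 700 nM.
Compound 2, `O=C(CN1CCN(c2c(Br)cnc3[nH]c(-c4ccccc4)nc23)CC1)Nc1nccs1`, gives 3000 nM.
Compound 3, `Cc1cc(CN2CCN(c3c(Br)cnc4[nH]c(-c5ccc(CN)cc5)nc34)CC2)no1`, gives 240 nM.

Among these three, compound 2 stands at the highest number. Its nearest neighbour is compound 1, whose value is lower by a margin beyond the scatter, and compound 3 lies further off still, also beyond the scatter.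

Compound 4, `CN(C)c1ccc(-c2nc3c(N4CCN(CC(=O)Nc5nccs5)CC4)c(Br)cnc3[nH]2)cc1`, has not yet been measured. It keeps the shared core of compound 2 and differs from it in one place: dimethylamino in place of hydrogen on an aromatic carbon. No pair of measured compounds isolates this change, so the expectation rests on a looser comparison: compound 1 carries the same dimethylamino group and gives the lower of the two numbers shown for it and compound 2, although it also differs elsewhere. On that basis the number for compound 4 is expected to come out lower than that of compound 2. In this assay the step expected for compound 4 is a 2.5-fold lower number from compound 2 to compound 4 (0.40 log units; beyond the scatter), of moderate size and beyond the scatter. The estimate for compound 4 in this assay is 1200 nM, within a range from 400 nM to 3500 nM.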

Compound 4, concentration for 50% growth inhibition: 480 nM
Compound 4: middle estimate off by 2.5-fold (0.40 log units), on the high side, and the stated range covers the measured number.
By their numbers in this assay, from the lowest: compounds 3, 4 and 1 (each within the scatter of the next, the first and the last beyond it); then compound 2.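

For the compounds shown here, the change from phenyl to 4-(dimethylamino)phenyl, read on its own in this assay, comes with a 6.3-fold lower number from compound 2 to compound 4 (0.80 log units; beyond the scatter), and this pair is the first to isolate dimethylamino in place of hydrogen at this position, para to a large group. With 4-(dimethylamino)phenyl held fixed, (1,3-thiazol-2-yl)carbamoyl in place of pyridin-4-yl gives a 1.5-fold lower number from compound 1 to compound 4 (0.16 log units; within the scatter), so the two groups on the saturated chain carbon cannot be told apart in this setting. The effect of dimethylamino therefore rests on this one pair, not on a wider pattern.

Nothing measured on these compounds explains the step. On these data alone, it remains open whether a smaller amine such as methylamino, or a methoxy group, at the same place would bring a similar step, and whether dimethylamino would do so alongside other groups on the saturated chain carbon.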